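The source may hold more compounds than are shown below. What is called first, only, known or untested is meant among the compounds shown, and "the series" means these compounds.

Compound 1 `COc1cc(-n2ncnc2-c2ccc(C)cc2)cc(OC)c1OC` was tested in a functional assay on K562 cells (Homo sapiens) for antiproliferative activity, read by MTT assay, with a stated time of 72 h; on this read-out lower numbers stand for stronger inhibition and higher numbers for weaker inhibition. In this assay compound 1 gives only the limit > 10000 nM, so no number places it. For the measured compounds named here, compound 2 `COc1cc(-n2ncnc2-c2cccc(F)c2)cc(OC)c1OC` is its one measured neighbour, and in this assay compound 2 likewise gives only the limit > 10000 nM. The step that the two limits leave unreadable from compound 1 to compound 2 therefore cannot be read, both values sitting at the limit of > 10000 nM in this assay, at which 2 of the 2 values shown sit. Compound 3 `CCOc1ccc(-c2ncnn2-c2cc(OC)c(OC)c(OC)c2)cc1` differs from compound 1 by ethoxy in place of methyl on an aromatic carbon. Going by the values given here, no measured step bears on this change, so nothing beyond the scatter is expected for the step that the limit leaves unreadable from compound 1 to compound 3 in this assay. Compound 3 is therefore expected to give 15000 nM, between 5000 nM and 50000 nM, most likely again only a limit.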

Compound 3, half-maximal inhibitory concentration: 20 nM
Compound 3: middle estimate off by 750-fold (2.88 log units), on the high side, and the stated range ends above it.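

In this assay, ethoxy in place of methyl on an aromatic carbon, para to a large group, gives an at least 500-fold lower number from compound 1 to compound 3 (2.69 log units; beyond the scatter). This position therefore affects the read-out strongly, which compounds 1 and 2 could not show. The size of the step remains a bound, because compound 1 gives only a limit: the limit of > 10000 nM in this assay, at which 2 of the 3 values shown sit.

The compounds shown leave open whether the ether oxygen or the added carbon accounts for the step. They also leave open how a propyl group, a longer alkoxy chain or an amine would read at this position.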